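The source may report more compounds than this note shows. Statements on the series, on what has been measured and on what is new or still open speak of the compounds shown alone.

Measured compounds in an assay on Jurkat E6.1 cells for inhibition of histone deacetylase 4 (Homo sapiens), read by fluorescence; on this read-out lower numbers stand for stronger inhibition and higher numbers for weaker inhibition: compound 1 `C[C@H](CN1CCC(F)CC1)NC(=O)c1ccc(-c2noc(C(F)(F)F)n2)cc1` at 100 nM; compound 2 `CCCN(CCC)C[C@@H](C)NC(=O)c1ccc(-c2noc(C(F)F)n2)cc1` at 19000 nM.

Compound 2 has the higher of the two numbers in this assay; compound 1 gives a lower value, and the gap lies beyond the scatter. The two differ in more than one place, so only the two values themselves can be compared.

Compound 3 `CCCN(CCC)C[C@@H](C)NC(=O)c1ccc(-c2noc(C)n2)cc1` follows from compound 2 by methyl in place of difluoromethyl on an aromatic carbon. Going by the values given here, no measured pair shows this change on its own. A step upward, beyond the scatter, is expected for the change from compound 2 to compound 3, as a 3.2-fold higher number from compound 2 to compound 3 (0.50 log units; beyond the scatter). Compound 3 is estimated at 60000 nM, within 15000 nM to 200000 nM, and the assay may well report only a limit.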

Compound 3, half-maximal inhibitory concentration: > 50000 nM
Compound 3: no number, only a limit; the forecaster's own chance of this, stated with the estimate: 50%; the middle value is on the limit's open side.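

In this assay, compound 3 reads > 50000 nM, which is a limit of the assay and not a number. Methyl in place of difluoromethyl on this aromatic carbon gives an at least 2.6-fold higher number from compound 2 to compound 3 (0.42 log units; beyond the scatter), the first single-place change in the series, and it shows that the read-out responds to the group at this position. The true size of the step stays unknown: the limit of > 50000 nM in this assay, at which 1 of the 3 values shown sits.

How trifluoromethyl compares with difluoromethyl here cannot be read, since compound 1 and compound 2 differ in more than one place. Also open, on these data alone, is how a cyclopropyl group or an amine at this position would read.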